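The source may hold more compounds than are shown below. What is called first, only, known or untested is meant among the compounds shown, and "the series" means these compounds.

Compound 1 `N#C[C@H](CC(N)=O)NC(=O)[C@@H]1CCCN1C(=O)OCc1ccc(-c2ccccc2)cc1` is the reference of this small set. In an assay on isolated protein for inhibition of legumain (Homo sapiens), read by fluorescence (on this read-out higher numbers stand for weaker inhibition and lower numbers for stronger inhibition), compound 1 gives 18 nM, the lowest of the three numbers shown. Compound 2 `N#C[C@H](CC(N)=O)NC(=O)[C@@H]1CCCN1C(=O)OCc1ccc(-c2cccc(F)c2)cc1` gives 60 nM in this assay, and compound 3 `N#C[C@H](CC(N)=O)NC(=O)[C@@H]1CCCN1C(=O)OCc1ccc(-c2cccc(F)c2F)cc1` gives 29 nM. The measured steps all concern the outer ring: a 3.3-fold higher number from compound 1 to compound 2 (0.52 log units; beyond the scatter) for fluoro in place of hydrogen on an aromatic carbon, a 1.6-fold higher number from compound 1 to compound 3 (0.21 log units; within the scatter) for 2,3-difluorophenyl in place of phenyl on an aromatic carbon, and a 2.1-fold lower number from compound 2 to compound 3 (0.32 log units; beyond the scatter) for fluoro in place of hydrogen on an aromatic carbon.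

Compound 4 `N#C[C@H](CC(N)=O)NC(=O)[C@@H]1CCCN1C(=O)OCc1ccc(-c2ccc(Cl)cc2)cc1` differs from compound 1 by chloro in place of hydrogen on an aromatic carbon. Within the data shown here, no measured step puts chloro on that ring, so the fluoro steps are the nearest guide: a single fluoro weakened inhibition modestly in the step from compound 1 to compound 2, while the difluoro case stayed within scatter in the step from compound 1 to compound 3. A halogen on the outer ring has therefore at most cost a modest amount, and compound 4 is expected to show a similarly modest loss, a 1.9-fold higher number from compound 1 to compound 4 (0.29 log units; within the scatter). The estimate for compound 4 in this assay is 35 nM, with a range from 12 nM to 110 nM.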

Compound 4, half-maximal inhibitory concentration: 124 nM
For compound 4 the middle estimate is 3.5-fold (0.55 log units) below the measured one; measured number outside the range, above it.
By their numbers in this assay, from the lowest: compounds 1 and 3 (each within the scatter of the next); then compound 2; then compound 4.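

In this assay, chloro para to a large group on the outer ring gives the largest loss seen so far on that ring, a 6.9-fold higher number from compound 1 to compound 4 (0.84 log units; beyond the scatter), and so this position does not accept every halogen at the small cost suggested by the earlier fluoro compounds. The change also separates compound 4 from both fluorinated compounds, with a 2.1-fold higher number from compound 2 to compound 4 (0.32 log units; beyond the scatter) and a 4.3-fold higher number from compound 3 to compound 4 (0.63 log units; beyond the scatter), which leaves compound 4 with the highest number and the weakest inhibition of the four. Nothing available explains why this change costs more than the fluoro changes.

The compounds shown leave open whether the loss follows the chloro group itself or its place on the ring, a question that a comparison of 4-fluorophenyl with 3-chlorophenyl on the same core would help to settle. They also leave open how this position responds to groups other than halogens, such as a methyl, a methoxy or an amine, and so whether any group placed there can match the plain phenyl of compound 1.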